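Hydroxy for amino on a compound already at the limit

The source may report more compounds than this note shows. Statements on the series, on what has been measured and on what is new or still open speak of the compounds shown alone.

In a functional assay on Vero cells (Chlorocebus sabaeus) for cytotoxicity (on this read-out lower numbers stand for stronger inhibition and higher numbers for weaker inhibition), compound 1 (`Nc1ccn([C@@H]2CC(F)(F)[C@H](CO)O2)c(=O)n1`) gives > 100000 nM, which is a limit and not a number. Its stereoisomer, compound 2 (`Nc1ccn([C@H]2CC(F)(F)[C@H](CO)O2)c(=O)n1`), gives > 100000 nM, again only a limit. Within the data shown here, compound 2 therefore has no number of its own, and the one value it can be set against is also a limit. Among the measured compounds shown here, the only measured step is a step that the two limits leave unreadable from compound 1 to compound 2. It reflects (the fact that compounds 1 and 2 differ only in the configuration as drawn), and with the limit of > 100000 nM in this assay, at which 2 of the 2 values shown sit, it offers no size to carry forward.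

Compound 3 (`O=c1nc(O)ccn1[C@H]1CC(F)(F)[C@H](CO)O1`) differs from compound 2 by hydroxy in place of amino on an aromatic carbon. For the measured compounds named here, no measured pair carries this change. Going by the values given here, the sole reference remains compound 2 at > 100000 nM, a limit, so no step beyond the usual scatter is expected in this assay, and no direction can be named. Compound 3 is expected to be reported as a limit as well. The estimated value for compound 3 is 100000 nM, with an expected range from 40000 nM to 200000 nM. This estimate means an expected a number no higher from compound 2 to compound 3 (the limit leaves the size open).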

Compound 3, half-maximal inhibitory concentration: > 100000 nM
Compound 3 gave a limit, no number; the forecaster's own chance of this, stated with the estimate: 90%; the middle value lies on the limit itself.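

In this assay compound 3 gives > 100000 nM, which is a limit and not a number. No step can be read between compound 2 and compound 3, because both stand at the same limit: the limit of > 100000 nM in this assay, at which 3 of the 3 values shown sit.

The compounds shown leave open what size, or even what direction, the change from amino to hydroxy has in this assay.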